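Swapping an Amino Side Chain for Chlorine

The source may report more compounds than this note shows. Statements on the series, on what has been measured and on what is new or still open speak of the compounds shown alone.

Of the compounds shown here, three sharing one core have been measured in an assay on K562 cells for displacement of a labelled ligand from Equilibrative nucleoside transporter 1 (Homo sapiens), read by flow cytometry, with a stated time of 45 min; a lower number here means a stronger inhibitor, a higher number a weaker inhibitor. Compound 1 `O=[N+]([O-])c1ccc(CSc2nc(NC3CCC3)nc3c2ncn3[C@@H]2O[C@H](CO)[C@@H](O)[C@H]2O)cc1` gives 33 nM, compound 2 `CCCCCNc1nc(SCc2ccc([N+](=O)[O-])cc2)c2ncn([C@@H]3O[C@H](CO)[C@@H](O)[C@H]3O)c2n1` gives 357 nM, and compound 3 `O=[N+]([O-])c1ccc(CSc2nc(NCCO)nc3c2ncn3[C@@H]2O[C@H](CO)[C@@H](O)[C@H]2O)cc1` gives 86 nM. Compound 3 thus stands second highest of the three: the gap a 2.6-fold higher number from compound 1 to compound 3 (0.42 log units; beyond the scatter) separates it from compound 1, and the gap a 4.2-fold lower number from compound 2 to compound 3 (0.62 log units; beyond the scatter) separates it from compound 2.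

Compound 4 `O=[N+]([O-])c1ccc(CSc2nc(Cl)nc3c2ncn3[C@@H]2O[C@H](CO)[C@@H](O)[C@H]2O)cc1` differs from compound 3 in one place: chloro in place of (2-hydroxyethyl)amino on an aromatic carbon. The group that leaves carries hydrogen-bond donors and acceptors; the chlorine that enters carries none.

For the measured compounds named here, none of the measured steps makes this exact change. The steps available, an 11-fold higher number from compound 1 to compound 2 (1.03 log units; beyond the scatter), a 2.6-fold higher number from compound 1 to compound 3 (0.42 log units; beyond the scatter) and a 4.2-fold lower number from compound 2 to compound 3 (0.62 log units; beyond the scatter), all keep the nitrogen attached to the ring and vary only what hangs from it, yet they already move the number by modest to large amounts. Removing the amino group entirely is a larger departure from compound 3 than any of those, so a step of comparable or greater size seems reasonable, and a weakening is expected as the more likely direction. The expected step is a 2.6-fold higher number from compound 3 to compound 4 (0.41 log units; beyond the scatter). Compound 4 is therefore estimated at 220 nM, within a range from 50 nM to 900 nM.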

Compound 4, inhibition constant: 11 nM
Beside the measured number, compound 4's estimate is 20-fold (1.30 log units) above it; measured number outside the range, below it.
By their numbers in this assay, from the lowest: compound 4; then compound 1; then compound 3; then compound 2.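

Chlorine on this aromatic carbon gives the lowest number of the four in this assay, so an amino side chain at this position is not needed for strong inhibition, even though the chloro group has no hydrogen-bond donors or acceptors. The earlier compounds shown here varied only what hangs from the nitrogen, whereas here the whole side chain is replaced, and the gain depends on which one leaves: a 7.8-fold lower number from compound 3 to compound 4 (0.89 log units; beyond the scatter) for (2-hydroxyethyl)amino, a 3.0-fold lower number from compound 1 to compound 4 (0.48 log units; beyond the scatter) for cyclobutylamino and a 32-fold lower number from compound 2 to compound 4 (1.51 log units; beyond the scatter) for pentylamino, all beyond the scatter. Nothing measured here accounts for these drops.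

The compounds shown leave open whether the low number belongs to chlorine itself or simply follows the loss of the amino side chain; a bromine, a methyl group or a plain hydrogen on the same aromatic carbon would help separate those two readings. From the compounds shown here alone, all four compounds also carry the same (4-nitrobenzyl)sulfanyl group, so it remains open whether the advantage of chlorine would survive with a different group there, such as a plain benzylsulfanyl.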